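A few compounds are considered here, and "the series" means these few. Any claim that something is new, unique, unknown or untested is made for them only; others in the source may bear on it.

Compound 1, `Cn1c(-c2ccc([N+](=O)[O-])cc2)nc2cc(C(F)(F)F)ccc21`: > 100000 nM
Compound 2, `COc1ccc(-c2nc3cc(C(C)=O)ccc3[nH]2)c(OC)c1`: > 100000 nM
Compound 3, `O=C(CN1CCCC1)Nc1ccc(-c2nc3ccccc3[nH]2)cc1`: 55000 nM

These three compounds were tested in an ADME assay on BHK cells (Mesocricetus auratus) for cytotoxicity, read by MTT assay, with a stated time of 96 h; on this read-out higher numbers stand for lower toxicity in this test and lower numbers for higher toxicity in this test. For compound 1 the value is a limit of the assay rather than a number; compound 1 sits at the limit of > 100000 nM in this assay, at which 2 of the 3 values shown sit. For compound 2 the value is likewise a limit. Compound 3 alone gives a numerical reading in this assay. Compound 4, `Cn1c(-c2ccc(N)cc2)nc2cc(C(F)(F)F)ccc21`, has not yet been tested. It differs from compound 1 in one place: amino in place of nitro on an aromatic carbon. For the measured compounds named here, no two measured compounds differ by a single change, so no measured step exists to lean on. The expected step is a number no higher from compound 1 to compound 4 (the limit leaves the size open), not beyond the scatter in either direction. Compound 4 is therefore estimated to give 100000 nM, with a range from 30000 nM to 300000 nM.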

Compound 4, half-maximal cytotoxic concentration: 85000 nM
Compound 4: the middle estimate sits 1.2-fold (0.07 log units) above what was measured, and the stated range covers the measured number.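

In this assay there is an at least 1.1-fold lower number from compound 1 to compound 4 (0.07 log units; that floor lies within the scatter) with amino in place of nitro on this aromatic carbon, para to a large group. At this position the change gives a numerical reading, which compound 1 did not give. The value of compound 1 is a limit, so the true size of the step cannot be read: the limit of > 100000 nM in this assay, at which 2 of the 4 values shown sit.

The compounds shown leave open how far the number really moves with this change. They also leave open what a carboxylic acid or a nitrile at the same place would give.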